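The compounds below may be only part of what the source reports. "The series", "measured", "known", "first", "only" and "open" are said of these compounds alone.

Working notes on the coumarin-bearing series in a functional assay on DU-145 cells (Homo sapiens) for cytotoxicity, read by MTT assay, with a stated time of 48 h; on this read-out lower numbers stand for stronger inhibition and higher numbers for weaker inhibition. Compound 1 `CCOC(=O)c1c(-c2cc3ccccc3oc2=O)nn(-c2ccccc2)c1C(=O)OCC` gives 57000 nM. Compound 2 `CCOC(=O)c1c(-c2cc3ccccc3oc2=O)nn(-c2ccc(C)c(C)c2)c1C(=O)OCC` gives 40000 nM. Compound 3 `CCOC(=O)c1c(-c2cc3ccccc3oc2=O)nn(-c2cccc(Cl)c2)c1C(=O)OCC` gives 35000 nM, the lowest of the three numbers, although the steps that separate it from the others remain within the scatter: a 1.6-fold lower number from compound 1 to compound 3 (0.21 log units; within the scatter) and a 1.1-fold lower number from compound 2 to compound 3 (0.06 log units; within the scatter). Compound 4 `CCOC(=O)c1c(-c2cc3ccccc3oc2=O)nn(-c2ccc(Br)cc2)c1C(=O)OCC` has not yet been measured; it differs from compound 3 by 4-bromophenyl in place of 3-chlorophenyl on an aromatic nitrogen. Going by the values given here, every measured step so far changes only the group on the same aromatic nitrogen, and none of them exceeds the scatter: a 1.4-fold lower number from compound 1 to compound 2 (0.15 log units; within the scatter), a 1.6-fold lower number from compound 1 to compound 3 (0.21 log units; within the scatter), a 1.1-fold lower number from compound 2 to compound 3 (0.06 log units; within the scatter). The expectation for compound 4 in this assay is therefore no step beyond the scatter, no change at the digits printed from compound 3 to compound 4 (within the scatter). Compound 4 is estimated at 35000 nM, within a range of 17000 nM to 70000 nM.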

Compound 4, half-maximal inhibitory concentration: 61000 nM
The estimate for compound 4 lay 1.7-fold (0.24 log units) below the measured number; measured number inside the range.
By their numbers in this assay, from the lowest: compounds 3, 2, 1 and 4 (each within the scatter of the next).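

In this assay, the bromo-bearing group on the aromatic nitrogen does not separate compound 4 from the others: a 1.7-fold higher number from compound 3 to compound 4 (0.24 log units; within the scatter), a 1.5-fold higher number from compound 2 to compound 4 (0.18 log units; within the scatter) and a 1.1-fold higher number from compound 1 to compound 4 (0.03 log units; within the scatter). All four aryl groups at this nitrogen therefore remain within the scatter of one another, so this position shows no ranking among them. No available evidence bears on why these groups read alike. Going by these compounds, whether an amine or a carboxylic acid on the phenyl ring would move the number beyond the scatter remains open, as does the effect of replacing an ethoxycarbonyl group on the shared core with a longer chain.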